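The source may hold more compounds than are shown below. What is called first, only, known or untested is meant among the compounds shown, and "the series" means these compounds.

Working notes on the series. For the measured compounds named here, compound 1 `Cn1cc(CN2CCC[C@H](OCc3cc(Cl)cc(Cl)c3)[C@@H]2c2ccccc2)cn1` is the only compound of the set with a number in an assay on isolated protein for activation of cGMP-dependent protein kinase 1 (Homo sapiens), read by ADP-Glo, with stated times of 120 min and 40 min; a higher number here means that more compound is needed for the effect, a lower number that less compound is needed; compound 1 gives 110000 nM there. Compound 2 `Clc1cc(Cl)cc(CO[C@H]2CCCN(Cc3ncco3)[C@H]2c2ccccc2)c1` gives only a limit, > 200000 nM, in this assay. Going by the values given here, the one measured step at this position, an at least 1.8-fold higher number from compound 1 to compound 2 (0.25 log units; that floor lies within the scatter), reaches a limit of > 200000 nM in this assay, at which 1 of the 2 values shown sits, and stays within the scatter.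

Compound 3 `COc1ccc(C(=O)O)cc1CN1CCC[C@H](OCc2cc(Cl)cc(Cl)c2)[C@@H]1c1ccccc1` differs from compound 1 by 5-carboxy-2-methoxyphenyl in place of 1-methyl-1H-pyrazol-4-yl on a saturated chain carbon bound to an amine nitrogen in a ring. Among the compounds with values here, no measured step covers a group of this kind, and the single step at this position bears only weakly on it. Compound 3 is therefore expected to sit near compound 1, at about 110000 nM (range 35000 nM to 200000 nM), with the step of no change at the digits printed from compound 1 to compound 3 (within the scatter) expected to stay within the scatter.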

Compound 3, half-maximal effective concentration: 123000 nM
Compound 3: the middle estimate sits 1.1-fold (0.05 log units) below what was measured, and the stated range covers the measured number.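

In this assay this position accepts 5-carboxy-2-methoxyphenyl, a six-membered aromatic ring of carbon only that brings a hydrogen-bond donor, in place of 1-methyl-1H-pyrazol-4-yl without a change beyond the scatter: a 1.1-fold higher number from compound 1 to compound 3 (0.05 log units; within the scatter). The step from the oxazole gives only a floor: an at least 1.6-fold lower number from compound 2 to compound 3 (0.21 log units; that floor lies within the scatter). One value of the set still rests on a limit: the limit of > 200000 nM in this assay, at which 1 of the 3 values shown sits.

On these data alone, whether any group on this chain carbon moves the number beyond the scatter stays open. Also open, as far as these compounds go, is whether an unsubstituted phenyl or an aminomethyl-substituted phenyl would read differently from 5-carboxy-2-methoxyphenyl.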